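The source may report more compounds than this note shows. Statements on the series, on what has been measured and on what is new or still open speak of the compounds shown alone.

Compound 1: `NCc1ccccc1NC(=O)c1cnc2ccccc2c1` — in a physicochemical assay for solubility (a lower number here means a less soluble compound, a higher number a more soluble compound), compound 1 gives 5 ug/mL.
Compound 2: `COC(=O)c1cccc(NC(=O)c2ccc(-c3ccccc3)cc2)c1` — in this assay compound 2 gives < 5 ug/mL.

Of the compounds shown here, two have been measured so far, and they do not share a single point of difference, so the two values can only be read side by side. Compound 1 sits at a low value. For compound 2 the result is not a number but a limit of the assay, (the limit of < 5 ug/mL in this assay, at which 1 of the 2 values shown sits), so its solubility is only known to be no more than the reading shows. For the measured compounds named here, no step between measured compounds is available to calibrate the change that follows.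

Compound 3, `NC(=O)c1cccc(NC(=O)c2ccc(-c3ccccc3)cc2)c1`, differs from compound 2 in one place: amino in place of methoxy on a carbonyl carbon. Since compound 2 stands at a limit, the direction of the step can only be upward or unchanged. The expectation is that the step of an at least 3.0-fold higher number from compound 2 to compound 3 (0.47 log units; beyond the scatter) goes upward by somewhat more than the usual scatter. Compound 3 is therefore estimated at 15 ug/mL, with a range from 3 ug/mL to 60 ug/mL.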

Compound 3, solubility: 25 ug/mL
For compound 3 the middle estimate is 1.7-fold (0.22 log units) below the measured one; the measured number falls inside the stated range.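

In this assay, amino in place of methoxy on a carbonyl carbon gives an at least 5.0-fold higher number from compound 2 to compound 3 (0.69 log units; beyond the scatter), so this position now has a change whose size can be stated. Only the lower end of that step is known, because compound 2 stands at a limit rather than at a number: the limit of < 5 ug/mL in this assay, at which 1 of the 3 values shown sits. The exchange is small, with methoxycarbonyl becoming carbamoyl and the rest of the molecule unchanged, yet it moves the reading beyond the scatter.

The compounds shown leave open whether this rise is specific to the amino group or would also appear with another group on this carbonyl carbon, such as a methylamino group or the hydroxyl of a carboxylic acid. From the compounds shown here alone, compound 1 differs from the other two in more than one place, so whether the same exchange would work on its core also remains unknown.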